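The source may report more compounds than this note shows. Statements on the series, on what has been measured and on what is new or still open speak of the compounds shown alone.

Measured compounds:

- compound 1, `COc1ccccc1C1C(C#N)=C(N)N(c2cc(OC)c(OC)c(OC)c2)C2=C1C(=O)CC(C)(C)C2`, 70%
- compound 2, `COc1cc(N2C(N)=C(C#N)C(c3cccs3)C3=C2CC(C)(C)CC3=O)cc(OC)c1OC`, 15%
- compound 3, `COc1cc(N2C(N)=C(C#N)C(c3ccc(O)cc3)C3=C2CC(C)(C)CC3=O)cc(OC)c1OC`, 90%

All three share one core and differ only in the group on a saturated ring carbon. In a functional assay on Ehrlich cells (Mus musculus) for cytotoxicity, tested at 50 ug/mL (a higher number here means a stronger effect of the compound at the concentration tested, a lower number a weaker effect), compound 3 gives the highest of the three numbers: its nearest neighbour is compound 1 a number 20 percentage points higher from compound 1 to compound 3 (beyond the scatter), its furthest compound 2 a number 75 percentage points higher from compound 2 to compound 3 (beyond the scatter). The remaining pair, from compound 1 to compound 2, shows a number 55 percentage points lower from compound 1 to compound 2 (beyond the scatter).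

Compound 4, `COc1cc(N2C(N)=C(C#N)C(c3ccccc3Cl)C3=C2CC(C)(C)CC3=O)cc(OC)c1OC`, has not yet been measured in this assay. It differs from compound 3 in one place: 2-chlorophenyl in place of 4-hydroxyphenyl on a saturated ring carbon.

Within the data shown here, no measured step carries exactly this change. Among the measured compounds shown here, two steps bear on it. The step from compound 1 to compound 3 shows that 4-hydroxyphenyl stands above 2-methoxyphenyl, a number 20 percentage points higher from compound 1 to compound 3 (beyond the scatter), and the step from compound 2 to compound 3 shows a large drop when 4-hydroxyphenyl is replaced, a number 75 percentage points higher from compound 2 to compound 3 (beyond the scatter). Since compound 4 loses the 4-hydroxyphenyl as well, a step downward beyond the scatter is expected, of a size nearer to the modest one than to the large one; it is estimated as a number 30 percentage points lower from compound 3 to compound 4 (beyond the scatter).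

Compound 4 is therefore estimated at 60%, within a range from 25% to 85%.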

Compound 4, a percentage reported as activity, at one concentration (the size of the read-out at that concentration, not a potency): 20%
Beside the measured number, compound 4's estimate is 40 percentage points above it, and the stated range ends above it.
By their numbers in this assay, from the lowest: compounds 2 and 4 (each within the scatter of the next); then compound 1; then compound 3.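

In this assay, keeping a six-membered aromatic ring of carbon on the saturated ring carbon does not preserve the read-out, since 2-chlorophenyl in place of 4-hydroxyphenyl gives a number 70 percentage points lower from compound 3 to compound 4 (beyond the scatter) and the earlier fall with thiophen-2-yl therefore cannot be tied to that ring type alone. Among these compounds, the substituent on the phenyl ring also matters on its own, as chloro in place of methoxy, the single change that separates 2-chlorophenyl from 2-methoxyphenyl, gives a number 50 percentage points lower from compound 1 to compound 4 (beyond the scatter) while 2-chlorophenyl in place of thiophen-2-yl gives only a number 5 percentage points higher from compound 2 to compound 4 (within the scatter) and sets no order between those two groups. Nothing given here accounts for these differences.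

The step from 4-hydroxyphenyl to 2-chlorophenyl changes both the substituent and its place on the phenyl ring, and the compounds shown cannot separate these two changes. From the compounds shown here alone, how an unsubstituted phenyl, or a phenyl carrying an amine or a carboxylic acid, would behave at this saturated ring carbon remains open, and these single-concentration read-outs give no potency for any of the compounds.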